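The source may report more compounds than this note shows. Statements on the series, on what has been measured and on what is new or still open speak of the compounds shown alone.

Three compounds have been measured in a functional assay on CCRF-CEM cells (Homo sapiens) for cytotoxicity, read by resazurin assay, with a stated time of 48 h; on this read-out lower numbers stand for stronger inhibition and higher numbers for weaker inhibition:

Compound 1 `CCOc1ccc(-n2nnc3n[nH]c(NC)c3c2=O)cc1` gives 12400 nM.
Compound 2 `CCOc1ccc(-n2nnc3n[nH]c(Nc4ccccc4)c3c2=O)cc1` gives 5920 nM.
Compound 3 `CCOc1ccc(NC(=O)/C(C#N)=C(\Nc2ccccc2)SC)cc1` gives 20300 nM.

Compound 3 sits at the highest number of the three: its gap to compound 1 lies within the usual scatter, while its gap to compound 2 lies beyond it. How the core of compound 3 differs from the core of compound 2 is not broken down here.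

Compound 4 `CCOc1ccc(NC(=O)/C(C#N)=C(\NC)SC)cc1` has not been measured. It differs from compound 3 by methyl in place of phenyl on an amine nitrogen. The same kind of change, (methyl in place of phenyl on a nitrogen on an aromatic ring), connects compound 2 and compound 1, and there it produced a 2.1-fold higher number from compound 2 to compound 1 (0.32 log units; beyond the scatter). The two places are not identical: in compound 2 the nitrogen sits on an aromatic ring with an aromatic carbon as its other neighbour, whereas in compound 3 it is an amine nitrogen whose other neighbour is a double-bonded chain carbon. The step is therefore the same kind of change, not the same change.

Starting from compound 3 at 20300 nM, a step of about a 2.0-fold higher number from compound 3 to compound 4 (0.29 log units; within the scatter) is expected, resting on the earlier step of a 2.1-fold higher number from compound 2 to compound 1 (0.32 log units; beyond the scatter). Compound 4 is thus estimated at 40000 nM, expected to fall between 15000 nM and 100000 nM.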

Compound 4, half-maximal inhibitory concentration: 9940 nM
For compound 4 the middle estimate is 4.0-fold (0.60 log units) above the measured one; measured number below the stated range.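

In this assay, putting methyl in place of phenyl on the amine nitrogen gives a 2.0-fold lower number from compound 3 to compound 4 (0.31 log units; beyond the scatter), so on this core the swap goes with a lower number, the opposite direction to the earlier step on the other core. The change therefore did not carry from one core to the other here, not even in its direction, and the gap between the two steps is larger than chance scatter would readily explain: the same change on two cores in this assay, a 2.1-fold higher number (0.32 log units; beyond the scatter) from compound 2 to compound 1 and a 2.0-fold lower number (0.31 log units; beyond the scatter) from compound 3 to compound 4, 4.3-fold (0.63 log units) apart, beyond the scatter of two such steps. This does not show why the steps differ, since each core offers a single pair, and the cores differ in more than one place, so nothing here singles out which part of them matters.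

From the compounds shown here alone, with only phenyl and methyl on this nitrogen, it stays open whether a longer chain, a benzyl or a cyclohexyl group would follow the trend of either core. A further pair on each core would also show whether the opposite directions hold beyond these four compounds.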